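The source may hold more compounds than are shown below. What is called first, only, known or untested is meant among the compounds shown, and "the series" means these compounds.

Measured compounds:
- compound 1, `CC(=O)Oc1cc2oc(-c3ccccc3)cc(=O)c2c(O)c1OC(C)=O`: 69300 nM
- compound 2, `CC(=O)Oc1cc2oc(-c3ccccc3)cc(=O)c2c(OC(C)=O)c1OC(C)=O`: 57200 nM

In a functional assay on KB 3-1 cells (Homo sapiens) for inhibition, with a stated time of 72 h (on this read-out lower numbers stand for stronger inhibition and higher numbers for weaker inhibition), compound 1 gives 69300 nM, the highest of the two numbers recorded so far. Compound 2 gives 57200 nM in this assay, and the two values sit close together: the change was a 1.2-fold lower number from compound 1 to compound 2 (0.08 log units; within the scatter), so there is no real difference to read from that pair.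

Compound 3, `CC(=O)Oc1c(OC(C)=O)c(O)c2c(=O)cc(-c3ccccc3)oc2c1Br`, has not yet been measured in this assay. Compared with compound 1 the change is bromo in place of hydrogen on an aromatic carbon. Among the measured compounds shown here, none of the measured steps involves a bromo group, and the one step that has been measured, acetyl in place of hydrogen on an oxygen on an aromatic ring, left the number essentially unchanged. There is therefore nothing in these data to predict a shift in either direction, and the shared core appears tolerant of small changes at its periphery. The expectation for compound 3 is a number similar to that of compound 1, a step of about a 1.3-fold lower number from compound 1 to compound 3 (0.10 log units; within the scatter), giving an estimate of 55000 nM with a likely range from 18000 nM to 160000 nM.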

Compound 3, half-maximal inhibitory concentration: 16200 nM
The estimate for compound 3 lay 3.4-fold (0.53 log units) above the measured number; measured number outside the range, below it.
By their numbers in this assay, from the lowest: compound 3; then compounds 2 and 1 (each within the scatter of the next).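

In this assay, among the compounds shown here, this aromatic carbon, ortho to an acetoxy group and para to a hydroxy group, is the first place on the shared core where a change moves the number beyond the scatter: bromo in place of hydrogen gives a 4.3-fold lower number from compound 1 to compound 3 (0.63 log units; beyond the scatter) and so counts as a modest but real gain in inhibition. For the compounds shown here, the only earlier step, a 1.2-fold lower number from compound 1 to compound 2 (0.08 log units; within the scatter) on swapping hydrogen for acetyl on an oxygen, had suggested that small changes around the core do little, and this result shows that this does not hold for every place on it. Nothing available explains why bromo at this carbon lowers the number.

On these data alone, whether chloro, iodo, a methyl group or an amine on this same carbon would lower the number as far, further or not at all remains open, so it cannot yet be said what about bromo matters here. Also open, as far as these compounds go, is whether bromo would give a step of similar size on compound 2, where the hydroxy group para to this carbon carries an acetyl instead.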